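Farnesyl thioether amides: cytotoxicity in pancreatic cancer cells

A few compounds are considered here, and "the series" means these few. Any claim that something is new, unique, unknown or untested is made for them only; others in the source may bear on it.

Measured compounds:
compound 1 `CC(C)=CCC/C(C)=C/CC/C(C)=C/CSC[C@H](NC(=O)CCCCCN1CCCC1)C(=O)NC1CCCCC1` — 5600 nM
compound 2 `CC(C)=CCC/C(C)=C/CC/C(C)=C/CSc1ccccc1C(N)=O` — > 20000 nM
compound 3 `CC(C)=CCC/C(C)=C/CC/C(C)=C/CSC[C@H](NC(=O)CCCCCN1CCN(C)CC1)C(=O)NC1CCCCCCC1` — 2500 nM

Of the compounds shown here, three sharing the farnesyl thioether tail have been tested in a functional assay on MIA PaCa-2 cells (Homo sapiens) for cytotoxicity, read by fluorescence, with a stated time of 48 h; on this read-out higher numbers stand for an effect only at larger amounts of compound and lower numbers for an effect already at smaller amounts. Compound 1 gives 5600 nM in this assay, the highest of the two numbers available. Compound 3 sits at 2500 nM, a gap to compound 1 that lies beyond the scatter of the assay. For compound 2 the assay reports only a limit, > 20000 nM (the limit of > 20000 nM in this assay, at which 1 of the 3 values shown sits), and no number.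

Compound 4 `CC(C)=CCC/C(C)=C/CC/C(C)=C/CSC[C@H](NC(=O)CCCCCN1CCCC1)C(=O)N1CCCC1` is not yet measured. It differs from compound 1 in one place (pyrrolidin-1-yl in place of cyclohexylamino on a carbonyl carbon); the change removes the amide hydrogen at the carboxamide end while the pyrrolidin-1-yl on the other chain is kept. Among the compounds with values here, no step between measured compounds probes this position, so the direction is open. The expected step from compound 1 to compound 4 is a 1.4-fold higher number from compound 1 to compound 4 (0.15 log units; within the scatter), a modest drift toward higher numbers that need not clear the scatter. Compound 4 is estimated to give 8000 nM in this assay, between 3000 nM and 20000 nM.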

Compound 4, half-maximal effective concentration: 10800 nM
Compound 4: the middle estimate sits 1.4-fold (0.13 log units) below what was measured; the range from low to high includes it.
By their numbers in this assay, from the lowest: compound 3; then compounds 1 and 4 (each within the scatter of the next). At a limit, above all of these: compound 2.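

In this assay, within the data shown here, the exchange of cyclohexylamino for pyrrolidin-1-yl on a carbonyl carbon gives a 1.9-fold higher number from compound 1 to compound 4 (0.29 log units; within the scatter) and is the first one-place step at this position. In this single pair, the loss of the amide hydrogen at the carboxamide end and the change of ring leave the two values within the scatter of each other. Nothing measured here bears on the reason for this outcome.

As far as these compounds go, whether a morpholin-4-yl, a dimethylamino group or a free carboxylic acid at this carbonyl would keep the value in the same range remains open. Compound 1 and compound 3 differ in more than one place, so the contributions of the carboxamide end and the amine on the other chain cannot be separated.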